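Turning the double bond of compound 1 from E to Z

The compounds below may be only part of what the source reports. "The series", "measured", "known", "first", "only" and "open" are said of these compounds alone.

In a functional assay on T98G cells (Homo sapiens) for cytotoxicity, read by MTT assay, with a stated time of 48 h (on this read-out higher numbers stand for weaker inhibition and lower numbers for stronger inhibition), compound 1 `C/C(=N\NC(=S)Nc1cccc(F)c1)c1ccccn1` gives 12 nM. This places it at the low end of the three numbers available, level within the scatter with compound 2 `C/C(=N\NC(=S)Nc1ccc(F)cc1)c1ccccn1` at 17 nM. Compound 3 `C/C(=N\NC(=S)Nc1cccc(I)c1)c1ccccn1` gives 61 nM, and the exchange of fluoro for iodo on an aromatic carbon amounts to a 5.1-fold higher number from compound 1 to compound 3 (0.71 log units; beyond the scatter).

The open question is compound 4 `C/C(=N/NC(=S)Nc1cccc(F)c1)c1ccccn1`, for which the structural change is this: the two compounds have the same atoms and bonds and differ only in configuration as drawn: 1 of 1 stereo elements differ; a double bond is drawn E in compound 1 and Z in compound 4. Among the measured compounds shown here, no measured pair tests a change of configuration. For the measured compounds named here, the one measured step, a 5.1-fold higher number from compound 1 to compound 3 (0.71 log units; beyond the scatter), involves a different kind of change and leaves the double bond as drawn, so it bears on the new step only indirectly. It shows that a single change in this small set can carry the number beyond the scatter, and that the change seen there led upward from the low end. On these data alone, the size and direction of a change in configuration remain unknown, so any expectation must be loose. A modest rise is the expected outcome, though a result level with compound 1 would not surprise. The expected move is a 2.3-fold higher number from compound 1 to compound 4 (0.37 log units; beyond the scatter). For compound 4 the estimated value is 28 nM, with an expected range from 8 nM to 120 nM.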

Compound 4, half-maximal inhibitory concentration: 12 nM
Beside the measured number, compound 4's estimate is 2.3-fold (0.37 log units) above it; the range from low to high includes it.
By their numbers in this assay, from the lowest: compounds 1, 4 and 2 (each within the scatter of the next); then compound 3.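

In this assay, the double bond gives the first test of configuration in this series, and the result is no change at the digits printed from compound 1 to compound 4 (within the scatter). At the printed level of precision, turning this bond from E to Z therefore leaves the number where it was, whereas exchanging fluoro for iodo on an aromatic carbon gives a 5.1-fold higher number from compound 1 to compound 3 (0.71 log units; beyond the scatter), so among the steps shown, only the change of halogen moves the number beyond the scatter. The comparison isolates the double bond, as nothing else separates the pair, and it rests on a single clean contrast: the fact that compounds 1 and 4 differ only in the configuration as drawn.

The compounds shown leave open whether the same insensitivity to configuration would hold with iodo in place of fluoro, as compound 3 is known only with the double bond drawn E, or whether it extends to the compound 2 pattern of substitution. They also leave open how the number would respond if an amine, a carboxylic acid or a longer chain took the place of the halogen on the aromatic ring, or if a carbonyl replaced the thiocarbonyl.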